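Halophenyl swaps on the thioether arm: cytotoxicity notes

The source may hold more compounds than are shown below. What is called first, only, known or untested is meant among the compounds shown, and "the series" means these compounds.

Three members of the series have been measured for tolerated concentration. Compound 1 `COc1cc(-c2nnc(SCc3ccccc3F)o2)ccc1O` gives 474000 nM in an ADME assay on cells (Mus musculus, strain BALB/c) for cytotoxicity, read by MTT assay, with a stated time of 24 h; a higher number here means that more compound is tolerated, a lower number that less compound is tolerated. Compound 2 `COc1cc(-c2nnc(SCc3ccc(F)cc3F)o2)ccc1O` gives 520000 nM in this assay, and compound 3 `COc1cc(-c2nnc(SCc3cccc(Cl)c3)o2)ccc1O` gives 470000 nM. Compound 3 holds the lowest of the three numbers, yet the two steps that reach it are a 1.0-fold lower number from compound 1 to compound 3 (0.00 log units; within the scatter) and a 1.1-fold lower number from compound 2 to compound 3 (0.04 log units; within the scatter), so the three values are indistinguishable within scatter; likewise a 1.1-fold higher number from compound 1 to compound 2 (0.04 log units; within the scatter) shows no separation.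

Compound 4 `COc1cc(-c2nnc(SCc3ccccc3Br)o2)ccc1O` is not yet measured. The change 2-bromophenyl in place of 3-chlorophenyl on a saturated chain carbon bound to a sulfur replaces one halophenyl with another on the saturated chain carbon bound to a sulfur. The two steps that bear on it, compound 1 to compound 3 and compound 2 to compound 3, each exchanged a halophenyl at this same place and both stayed within scatter. The expectation for this assay is therefore a step of no change at the digits printed from compound 3 to compound 4 (within the scatter), with no direction beyond scatter.

Compound 4 is estimated at 470000 nM, in the range 280000 nM to 780000 nM.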

Compound 4, half-maximal cytotoxic concentration: 363000 nM
Beside the measured number, compound 4's estimate is 1.3-fold (0.11 log units) above it; low and high end bracket the measured number.
By their numbers in this assay, from the lowest: compounds 4, 3, 1 and 2 (each within the scatter of the next).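

Working from this assay, the series now includes a bromine-bearing ring on a saturated chain carbon bound to a sulfur, and the exchange stays unresolved in all three comparisons: a 1.3-fold lower number from compound 3 to compound 4 (0.11 log units; within the scatter) and a 1.4-fold lower number from compound 2 to compound 4 (0.16 log units; within the scatter) and also a 1.3-fold lower number from compound 1 to compound 4 (0.12 log units; within the scatter) all remain inside the usual variation. The 2-fluorophenyl, 2,4-difluorophenyl, 3-chlorophenyl and 2-bromophenyl groups are therefore not separated at this place, and this now holds for bromo in place of fluoro on an aromatic carbon as well. Nothing available offers an explanation for how closely these numbers sit.

Still open, on these data alone, is whether a group other than a halophenyl at this place, such as an amine, a carboxylic acid or a longer chain, would give a step beyond the scatter. The compounds shown also all share one core, so the effect of any change to it on this read-out remains unknown.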